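Cytotoxicity limits in one series of four compounds

The source may report more compounds than this note shows. Statements on the series, on what has been measured and on what is new or still open speak of the compounds shown alone.

Compound 2 `CC(=O)c1ccc(NC(=O)C(=O)NC(c2nc(C)c(CO)s2)C2CCCCN2)cc1` in an ADME assay on TZM-b1 cells (Homo sapiens) for cytotoxicity, read by XTT assay, with a stated time of 3 days (on this read-out lower numbers stand for higher toxicity in this test and higher numbers for lower toxicity in this test), gives > 86000 nM, a limit of the assay. Compound 1 `Cc1nc(C(NC(=O)C(=O)Nc2ccc(F)c(F)c2)C2CCCCN2)sc1CO` gives > 87000 nM, also a limit. Compound 3 `CC(=O)c1ccc(NC(=O)C(=O)NC(c2nc(C)c(CCO)s2)C2CCCCN2)cc1` gives > 77300 nM, again a limit. The change from compound 2 to compound 1 is 3,4-difluorophenyl in place of 4-acetylphenyl on an amide-type nitrogen and gives a step that the two limits leave unreadable from compound 2 to compound 1. The cores of compound 2 and compound 3 differ by hydroxymethyl in place of hydroxy on a saturated chain carbon bound to an aromatic carbon, with a step that the two limits leave unreadable from compound 2 to compound 3. Compound 4 `Cc1nc(C(NC(=O)C(=O)Nc2ccc(F)c(F)c2)C2CCCCN2)sc1CCO` is not yet measured; it differs from compound 3 by 3,4-difluorophenyl in place of 4-acetylphenyl on an amide-type nitrogen, the same change as from compound 2 to compound 1, made at the same place. Since the earlier step rests only on the limits the limit of > 86000 nM in this assay, at which 1 of the 3 values shown sits, and (the limit of > 87000 nM in this assay, at which 1 of the 3 values shown sits), and compound 3 sits at the limit of > 77300 nM in this assay, at which 1 of the 3 values shown sits, the step in this assay is expected to be a step that the limit leaves unreadable from compound 3 to compound 4. Compound 4 is estimated at 100000 nM.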

Compound 4, half-maximal cytotoxic concentration: > 78200 nM
Compound 4: a limit, no number; the forecaster's own chance of this, stated with the estimate: 90%; the middle value does not contradict the limit.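

Among these compounds, compound 4, like compound 3 and compound 1, gives only a limit in this assay, so no step from either of them to compound 4 can be read. Whether either change alters cytotoxicity, and at what concentration any of these compounds becomes toxic, stays open.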